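The source may report more compounds than this note shows. Statements on the series, on what has been measured and on what is new or still open speak of the compounds shown alone.

Measured so far in a functional assay on NCI-H23 cells (Homo sapiens) for inhibition, read by sulforhodamine B assay, with a stated time of 48 h, tested at 1 uM; a higher number here means a weaker effect of the compound at the concentration tested, a lower number a stronger effect:
compound 1 `O=C(Nc1cccc(-n2cc(-c3ccncc3)c(-c3cc(O)cc(Cl)c3)n2)c1)Nc1ccc(Cl)c(C(F)(F)F)c1` gives 96%
compound 2 `O=C(Nc1cccc(-n2cc(-c3ccncc3)c(-c3cc(O)cc(Cl)c3)n2)c1)Nc1ccc(Cl)c(Cl)c1` gives 96%
compound 3 `COc1cc(Cl)cc(-c2nn(-c3cccc(NC(=O)Nc4cc(C(F)(F)F)cc(C(F)(F)F)c4)c3)cc2-c2ccncc2)c1` gives 8%

Compound 2 stands level with compound 1; the pair gives the highest numbers of the three, and compound 3 lies far lower. Among the measured compounds shown here, the one measured step, no change at the digits printed from compound 1 to compound 2 (within the scatter), sits on the urea aryl and does not touch the oxygen.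

Compound 4 `COc1cc(Cl)cc(-c2nn(-c3cccc(NC(=O)Nc4ccc(Cl)c(Cl)c4)c3)cc2-c2ccncc2)c1` arises from compound 2 by methyl in place of hydrogen on an oxygen on an aromatic ring. For the measured compounds named here, no measured step covers methyl entering on this oxygen; compound 3, which carries the methoxy group, differs from compound 2 in a second place as well, so its value only hints that a large downward move is possible. The step is therefore expected to be roughly a number 56 percentage points lower from compound 2 to compound 4 (beyond the scatter), though with much uncertainty. For compound 4 the estimate is 40%, with a range from 5% to 92%.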

Compound 4, a percentage reported as activity, at one concentration (the size of the read-out at that concentration, not a potency): 89%
Beside the measured number, compound 4's estimate is 49 percentage points below it; low and high end bracket the measured number.
By their numbers in this assay, from the lowest: compound 3; then compounds 4, 1 and 2 (each within the scatter of the next).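

Methyl in place of hydrogen on this oxygen gives a number 7 percentage points lower from compound 2 to compound 4 (within the scatter) in this assay and so leaves the read-out without a change beyond the scatter. The methoxy group alone therefore does not go with a low number: compound 4 carries it and gives 89% against compound 3, which carries it on a different urea aryl and gives 8% in the same assay. No evidence on the origin of this result is at hand.

Open, on these data alone, is whether the urea aryl of compound 3 gives the same low number with the hydroxy group in place of methoxy. Also open, as far as these compounds go, is how an amine or a longer chain such as ethoxy would read at this position.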